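Swapping the aryl group on the amide of a shared core

The compounds below may be only part of what the source reports. "The series", "measured", "known", "first", "only" and "open" are said of these compounds alone.

Of the compounds shown here, three built on one shared core have been tested in an assay (strain Wistar) for displacement of a labelled ligand from adenosine receptor A1 (Rattus norvegicus), read by scintillation counting; on this read-out higher numbers stand for weaker inhibition and lower numbers for stronger inhibition. Compound 1 `COc1ccc(Cl)cc1C(=O)Nc1nc(-c2ccccc2)nc2c1nnn2Cc1ccccc1` gives 7150 nM. Compound 2 `O=C(Nc1nc(-c2ccccc2)nc2c1nnn2Cc1ccccc1)c1ccoc1` gives 10 nM. Compound 3 `O=C(Nc1nc(-c2ccccc2)nc2c1nnn2Cc1ccccc1)c1cccc(F)c1` gives 22 nM, the second highest of the three numbers, with compound 2 nearest to it and compound 1 furthest away. The step of a 330-fold lower number from compound 1 to compound 3 (2.51 log units; beyond the scatter) was large, while the step of a 2.2-fold higher number from compound 2 to compound 3 (0.34 log units; beyond the scatter) was modest.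

Compound 4 `O=C(Nc1nc(-c2ccccc2)nc2c1nnn2Cc1ccccc1)c1ccc(C(F)(F)F)cc1` differs from compound 3 in one place: 4-(trifluoromethyl)phenyl in place of 3-fluorophenyl on a carbonyl carbon. For the measured compounds named here, no measured step exchanges one fluorine-bearing phenyl ring for another. The steps that touch the same position are a 330-fold lower number from compound 1 to compound 3 (2.51 log units; beyond the scatter), which was large, and a 2.2-fold higher number from compound 2 to compound 3 (0.34 log units; beyond the scatter), which was modest, so the group on the carbonyl carbon can shift this assay a great deal or only a little. Both the leaving and the entering group are a six-membered aromatic ring of carbon only carrying fluorine, and the step of a 1.8-fold higher number from compound 3 to compound 4 (0.26 log units; within the scatter) is expected to be modest at most. Compound 4 is therefore estimated to give 40 nM in this assay, within a range from 10 nM to 160 nM.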

Compound 4, inhibition constant: 123 nM
Estimate against measurement, compound 4: 3.1-fold (0.49 log units) below; the measured number falls inside the stated range.
By their numbers in this assay, from the lowest: compound 2; then compound 3; then compound 4; then compound 1.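

Even a swap between two fluorine-bearing phenyl rings is not silent at this position: in this assay there is a 5.6-fold higher number from compound 3 to compound 4 (0.75 log units; beyond the scatter) even though the ring itself stays the same. The 4-(trifluoromethyl)phenyl group gives up ground against the much smaller furan-3-yl, with a 12-fold higher number from compound 2 to compound 4 (1.09 log units; beyond the scatter), yet it remains far better than the 5-chloro-2-methoxyphenyl group, with a 58-fold lower number from compound 1 to compound 4 (1.76 log units; beyond the scatter), so this amide position separates these groups over a wide span. Nothing available here explains these shifts.

This step changes both the fluorine-bearing group and its place on the ring, so 4-fluorophenyl and 3-(trifluoromethyl)phenyl would be needed to tell those two changes apart. As far as these compounds go, how a phenyl ring carrying an amine or a carboxylic acid would behave at this position also remains open.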